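Fluorobenzyl swap on a stable amine: compound 3 to compound 4

This account rests on a few compounds, and the source may have more. Where it says the series, first, only, none or still open, it means among the compounds named here.

Measured so far in an ADME assay on microsomes from liver (Homo sapiens) for metabolic stability, with a stated time of 30 min; a higher number here means that more of the compound is left, a lower number that less of the compound is left:
- compound 1 `COc1nc2c(cc1Nc1cccc(Cl)c1F)c(=O)c(C(=O)O)cn2[C@H](CO)C(C)C`: "not determined" (no result reported)
- compound 2 `COc1nc2c(cc1NCc1cccc(Cl)c1F)c(=O)c(C(=O)O)cn2[C@H](CO)C(C)C`: "not determined" (no result reported)
- compound 3 `COc1nc2c(cc1NCc1ccc(F)cc1)c(=O)c(C(=O)O)cn2[C@H](CO)C(C)C`: 87%

Among the compounds with values here, compound 3 holds the only number, so it cannot yet be ranked against anything. Within the data shown here, no pair of measured compounds shows a step, and the expectation has only one measured point to rest on.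

Next in this assay is compound 4 `COc1nc2c(cc1NCc1ccccc1F)c(=O)c(C(=O)O)cn2[C@H](CO)C(C)C`. The change is 2-fluorophenyl in place of 4-fluorophenyl on a saturated chain carbon bound to a nitrogen on an aromatic ring. The two compounds have the same atoms, joined differently.

With compound 3 at 87% and so small a change, no large shift is anticipated. The estimated change, a number 5 percentage points lower from compound 3 to compound 4 (within the scatter), is expected to lean slightly downward and to stay within the usual scatter. For compound 4 the estimate is 82%, with an expected range of 67% to 94%.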

Compound 4, percent of the compound remaining: 97%
Compound 4: the middle estimate sits 15 percentage points below what was measured; the measured number lies above the stated range.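

In this assay, 2-fluorophenyl in place of 4-fluorophenyl on a saturated chain carbon bound to a nitrogen on an aromatic ring gives a number 10 percentage points higher from compound 3 to compound 4 (within the scatter), the first step the series offers at this position. The two isomers therefore cannot be told apart in this read-out, and this one pair gives no sign that the fluorine's place on the phenyl ring matters here. Nothing available bears on why the result came out this way.

Compound 1 and compound 2 report no result, so steps involving them cannot be read. Also open, from the compounds shown here alone, is whether this position stays equally insensitive to a group other than a fluorophenyl, such as an unsubstituted phenyl, a pyridyl ring or a longer chain between the amine nitrogen and the ring.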